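A piperazine sulfonamide variant of a receptor ligand

The source may hold more compounds than are shown below. What is called first, only, known or untested is meant among the compounds shown, and "the series" means these compounds.

Measured compounds:
compound 1 `Cc1ccc(S(=O)(=O)N(C)CC(C)C)cc1C#Cc1cc(Cl)ccc1OCC(=O)O` — 4.2 nM
compound 2 `O=C(O)COc1ccc(Cl)cc1C#Cc1ccc(Cl)cc1` — 60 nM

In an assay on CHO cells for displacement of a labelled ligand from prostaglandin D2 receptor 2 (Homo sapiens), read by scintillation counting (a lower number here means a stronger inhibitor, a higher number a weaker inhibitor), compound 1 gives the lower of the two numbers, and the gap to compound 2 lies beyond the usual scatter, so compound 1 stands as the stronger inhibitor of the pair. Compound 3 `Cc1ccc(S(=O)(=O)N2CCN(C)CC2)cc1C#Cc1cc(Cl)ccc1OCC(=O)O` is not yet measured. It differs from compound 1 in one place: 4-methylpiperazin-1-yl in place of isobutyl(methyl)amino on a sulfonyl sulfur. Among the measured compounds shown here, no measured pair shows this kind of change, so the expectation rests on compound 1 alone. A small step toward a weaker inhibitor is expected, a 2.4-fold higher number from compound 1 to compound 3 (0.38 log units; beyond the scatter), possibly within the scatter. Compound 3 is therefore estimated at 10 nM, in the range 3 nM to 40 nM.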

Compound 3, inhibition constant: 21 nM
For compound 3 the middle estimate is 2.1-fold (0.32 log units) below the measured one; the range from low to high includes it.
By their numbers in this assay, from the lowest: compound 1; then compound 3; then compound 2.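

In this assay the position on the sulfonyl sulfur responds to the amine it carries: 4-methylpiperazin-1-yl in place of isobutyl(methyl)amino gives a 5.0-fold higher number from compound 1 to compound 3 (0.70 log units; beyond the scatter) and so the open-chain group gives the stronger inhibitor of this pair. The step is modest, so the ring is tolerated at this place. Nothing available here accounts for the step. Still open, on these data alone, is whether a piperidine, with carbon in place of the ring's methylated nitrogen, would match compound 1, and whether a shorter chain such as dimethylamino would hold its number.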